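Swapping a Five-Membered Ring for Fluorophenyl: Cytotoxicity Outlook

The source may hold more compounds than are shown below. What is called first, only, known or untested is meant among the compounds shown, and "the series" means these compounds.

Measured compounds:
- compound 1, `Cc1cc(C)cc(S(=O)(=O)c2c(C(=O)NCC(=O)NCCn3c(C)cnc3[N+](=O)[O-])[nH]c3ccc(Cl)cc23)c1`: 24500 nM
- compound 2, `Cc1cc(C)cc(S(=O)(=O)c2c(C(=O)NC(C)C(=O)NC(C)c3ccccc3F)[nH]c3ccc(Cl)cc23)c1`: 15200 nM
- compound 3, `Cc1cc(C)cc(S(=O)(=O)c2c(C(=O)NC(C)C(=O)NC(C)c3ccccc3)[nH]c3ccc(Cl)cc23)c1`: 21700 nM

In an ADME assay on MT4 cells (Homo sapiens) for cytotoxicity, read by MTT assay (on this read-out lower numbers stand for higher toxicity in this test and higher numbers for lower toxicity in this test), compound 1 gives 24500 nM, the highest of the three numbers, yet its gaps to compound 3 and to compound 2 both lie within the scatter, so the three compounds cannot be told apart by toxicity here. Going by the values given here, the only single-point step among them, a 1.4-fold higher number from compound 2 to compound 3 (0.15 log units; within the scatter), is also within the scatter.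

Compound 4, `Cc1cc(C)cc(S(=O)(=O)c2c(C(=O)NCC(=O)NCc3ccccc3F)[nH]c3ccc(Cl)cc23)c1`, is derived from compound 1 by the change (a group of 7 heavy atoms (6 carbon, 1 fluorine; one six-membered aromatic ring of carbon only) in place of a group of 10 heavy atoms (5 carbon, 3 nitrogen, 2 oxygen; one five-membered aromatic ring with 2 hetero atoms), on a saturated chain carbon bound to an amide-type nitrogen). Among the compounds with values here, no measured step concerns exactly this replacement. The nearest guide is compound 2, which already carries the 2-fluorophenyl group and gives 15200 nM, a number within the scatter of compound 1, while the step of a 1.4-fold higher number from compound 2 to compound 3 (0.15 log units; within the scatter) shows that the fluoro itself did little. Compound 4 is therefore expected to show no step beyond the scatter, a 1.4-fold lower number from compound 1 to compound 4 (0.13 log units; within the scatter), and its estimated value in this assay is 18000 nM, with a likely range from 7000 nM to 45000 nM.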

Compound 4, half-maximal cytotoxic concentration: > 47300 nM
Compound 4 ended at the assay's limit; the forecaster's own chance of this, stated with the estimate: 10%; middle value at least 2.6-fold (0.41 log units) away from the limit.
By their numbers in this assay, from the lowest: compounds 2, 3 and 1 (each within the scatter of the next). At a limit, above all of these: compound 4.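

In this assay compound 4 gives > 47300 nM, which is a limit of the assay and not a number. Placing 2-fluorophenyl on a saturated chain carbon bound to an amide-type nitrogen, where the group with the five-membered aromatic ring stood, gives an at least 1.9-fold higher number from compound 1 to compound 4 (0.28 log units; that floor lies within the scatter). That floor alone does not set the two compounds apart, but the change brings no lower number, so this replacement shows no sign of higher toxicity in this test.

As far as these compounds go, how far compound 4 truly lies from compound 1 remains unknown, as its reading gives only a limit. The compounds shown also leave open how a pyridine ring, an amine or a carboxylic acid would read at this same place on the chain.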